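From Cyano to Methyl on Selenium

A few compounds are considered here, and "the series" means these few. Any claim that something is new, unique, unknown or untested is made for them only; others in the source may bear on it.

In a functional assay on HCT-116 cells (Homo sapiens) for antiproliferative activity, read by MTT assay, with a stated time of 48 h (a higher number here means a weaker inhibitor, a lower number a stronger inhibitor), compound 1 (`COc1ccc(N(C)c2ccnc(Cl)n2)cc1OCCBr`) gives 5670 nM and compound 2 (`COc1ccc(N(C)c2cc(C)nc(C)n2)cc1`) gives 1320 nM. Compound 3 (`Cc1cc(N(C)c2ccc([Se]C#N)cc2)nc(C)n1`) gives 245 nM, the lowest number of the three, and its gaps to both others lie beyond the scatter.

The next structure, compound 4 (`C[Se]c1ccc(N(C)c2cc(C)nc(C)n2)cc1`), carries methyl in place of cyano on a selenium. Going by these compounds, its result in this assay is still open.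

Within the data shown here, only one measured step bears on this change, and only indirectly. That step is a 5.4-fold lower number from compound 2 to compound 3 (0.73 log units; beyond the scatter), a modest move beyond the scatter that introduced the group holding both selenium and cyano. Among the measured compounds shown here, it cannot show how much of the move belongs to the selenium and how much to the cyano, and no measured pair changes the group on selenium alone. On these data alone, since the cyano leaves again, part of a 5.4-fold lower number from compound 2 to compound 3 (0.73 log units; beyond the scatter) is expected to be lost, although how much is unknown. The expected move is therefore modest and toward a higher number, estimated as a 1.8-fold higher number from compound 3 to compound 4 (0.26 log units; within the scatter), and a result within the scatter would not be surprising. Compound 4 is estimated at 450 nM, with an expected range from 90 nM to 2200 nM.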

Compound 4, half-maximal inhibitory concentration: 465 nM
Beside the measured number, compound 4's estimate is 1.0-fold (0.01 log units) below it; measured number inside the range.
By their numbers in this assay, from the lowest: compounds 3 and 4 (each within the scatter of the next); then compound 2; then compound 1.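

In this assay, among these compounds, the first step that changes only the group on selenium gives a 1.9-fold higher number from compound 3 to compound 4 (0.28 log units; within the scatter), so the exchange of cyano for methyl at this position does not separate compound 3 from compound 4, and the nitrile is not needed to stay within the scatter of the value of compound 3. The second new step, a 2.8-fold lower number from compound 2 to compound 4 (0.45 log units; beyond the scatter), lies beyond the scatter and shows a modest move with a selenium-bearing group that holds no cyano, a part of the earlier step that could not be isolated while selenium and cyano entered together. Nothing available explains why the number responds so little to the change on selenium, or why it moves from compound 2 to compound 4.

Going by these compounds, with only cyano and methyl on selenium, it remains open whether an ethyl group, a longer chain or a phenyl ring there would also stay within the scatter of these two compounds. On these data alone, it is also open whether selenium itself matters, a question that a sulfur atom carrying the same methyl group would address.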